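The source may report more compounds than this note shows. Statements on the series, on what has been measured and on what is new or still open speak of the compounds shown alone.

Compound 1 `Cc1nnc(SCC(=O)N/N=c2/scc(-c3ccccc3)n2-c2ccccc2)s1` gives 63.9% in a functional assay on C6 cells (Rattus norvegicus) for cytotoxicity, read by MTT assay, with a stated time of 24 h, tested at 50 ug/mL; a higher number here means a weaker effect of the compound at the concentration tested, a lower number a stronger effect.
Compound 2 `Cn1nnnc1SCC(=O)N/N=c1/scc(-c2ccc([N+](=O)[O-])cc2)n1-c1ccccc1` gives 69.2% in this assay.

Of the compounds shown here, two have been measured in this assay, and their numbers sit close together. Compound 2 has the higher of the two figures, but compound 1 lies only a few points away, a gap that falls within the usual scatter of such measurements, so the two cannot be told apart on this evidence. Among the measured compounds shown here, both compounds share the same core and differ in two places at once, so no single step between measured compounds can be drawn from them.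

Compound 3 `Cn1nnnc1SCC(=O)N/N=c1/scc(-c2ccccc2)n1-c1ccccc1` remains to be measured. It differs from compound 2 in one place: hydrogen in place of nitro on an aromatic carbon. For the measured compounds named here, no measured pair shows this change on its own, so there is no step to lean on. With both measured compounds close together, the expectation for this change is a small step, in no particular direction, and none beyond the scatter. The estimate means a step of a number 4.2 percentage points lower from compound 2 to compound 3 (within the scatter), expected to stay within the scatter. Compound 3 is accordingly expected to give about 65%, with a range from 50% to 80%.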

Compound 3, a percentage reported as activity, at one concentration (the size of the read-out at that concentration, not a potency): 56.2%
Compound 3: the middle estimate sits 8.8 percentage points above what was measured; measured number inside the range.
By their numbers in this assay, from the lowest: compounds 3, 1 and 2 (each within the scatter of the next, the first and the last beyond it).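

Going from 4-nitrophenyl to phenyl gives the first single change that can be read in (this assay), with (a number 13 percentage points lower from compound 2 to compound 3 (beyond the scatter)) as its size, and since a lower number here means a stronger effect, the aromatic carbon that carries hydrogen goes with the stronger effect at the concentration tested. The change on the sulfur, by contrast, comes to (a number 7.7 percentage points lower from compound 1 to compound 3 (within the scatter)), so with phenyl in place the 1-methyl-1H-tetrazol-5-yl and 5-methyl-1,3,4-thiadiazol-2-yl groups cannot be told apart in this read-out. Nothing at hand bears on the reason for the step at the aromatic carbon.

The compounds shown leave open how a chlorine, a methoxy group or an amine on that same aromatic carbon would compare with hydrogen and nitro, and so whether nitro stands apart or any group there would do the same. They also leave open whether the step from nitro to hydrogen would recur with the 5-methyl-1,3,4-thiadiazol-2-yl group on the sulfur, and what a longer chain or a carboxylic acid there would give.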